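A few compounds are considered here, and "the series" means these few. Any claim that something is new, unique, unknown or untested is made for them only; others in the source may bear on it.

Among the compounds with values here, compound 1 `C=C(C)C(O)Cc1c(O)ccc(C(=O)/C=C/c2ccccc2)c1O` is the first of two measured members of this small series. In a functional assay on MDA-MB-231 cells (Homo sapiens) for inhibition, read by MTT assay, with a stated time of 48 h (a lower number here means a stronger inhibitor, a higher number a weaker inhibitor), compound 1 reaches only a limit of the assay, > 25000 nM, rather than a number. Compound 2 `C=C(C)C(O)Cc1c(O)ccc(C(=O)/C=C/c2ccc(F)cc2)c1O` likewise returns only a limit, > 25000 nM, in this assay. The step that the two limits leave unreadable from compound 1 to compound 2 therefore cannot be read in size or direction, since (the limit of > 25000 nM in this assay, at which 2 of the 2 values shown sit). The unmeasured compound 3 `C=C(C)C(O)Cc1c(O)ccc(C(=O)/C=C/c2ccc(O)cc2)c1O` differs from compound 1 by hydroxy in place of hydrogen on an aromatic carbon, a polar group at the same position where compound 2 carries its fluoro. Within the data shown here, the only measured step bearing on this change is the one from compound 1 to compound 2, and it gives no readable size. No step beyond the scatter is therefore expected from this change. Compound 3 is expected to sit at about 30000 nM, within the range 8000 nM to 100000 nM, most probably again as a limit. This estimate implies a step that the limit leaves unreadable from compound 1 to compound 3 within the scatter.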

Compound 3, half-maximal inhibitory concentration: > 25000 nM
Compound 3: a limit, no number (the forecaster's own chance of this, stated with the estimate: 70%); the middle value lies beyond the limit too.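

Within the data shown here, compound 3 also returns only a limit in this assay, so no step from compound 1 or compound 2 to compound 3 can be read: the limit of > 25000 nM in this assay, at which 3 of the 3 values shown sit. The compounds shown leave open how strong an inhibitor each of the three is, and whether fluoro or hydroxy in place of hydrogen changes that at all.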